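Cyclopropyl for isopropyl on the amide-type nitrogen

The source may report more compounds than this note shows. Statements on the series, on what has been measured and on what is new or still open speak of the compounds shown alone.

Measured so far in an ADME assay on microsomes from liver (Rattus norvegicus) for metabolic stability, with a stated time of 60 min; on this read-out higher numbers stand for a more stable compound and lower numbers for a less stable compound
compound 1 `O=C(O)c1cc(-c2cccc(COc3ccc4c(c3)CN(c3ccccc3)C4=O)c2)ccc1Cl` gives 100%
compound 2 `CC(C)N1Cc2cc(OCc3cccc(-c4ccc(Cl)c(C(=O)O)c4)c3)ccc2C1=O` gives 91%
compound 3 `O=C(O)c1cc(-c2cccc(COc3ccc4c(c3)CCN(C3CCCC3)C4=O)c2)ccc1Cl` gives 36%

Compound 2 (91%) lies within the scatter of compound 1 (100%), so these two share the top of the set. Compound 3 (36%) lies far lower, well beyond the scatter from both. Going by the values given here, compound 3 differs from compound 2 in more than one place, so it gives no clean step here and serves only as a reminder that low numbers occur in this small set.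

The next compound is compound 4 (`O=C(O)c1cc(-c2cccc(COc3ccc4c(c3)CN(C3CC3)C4=O)c2)ccc1Cl`), not yet measured. The change (cyclopropyl in place of isopropyl on an amide-type nitrogen in a ring) puts cyclopropyl in place of isopropyl on an amide-type nitrogen in a ring. Among the compounds with values here, one measured step bears on this position (a number 9 percentage points lower from compound 1 to compound 2 (within the scatter)). It replaced phenyl with isopropyl on the same nitrogen and stayed within the scatter. Within the data shown here, that is a single step, and no measured compound yet carries cyclopropyl at this place. Even so, no change beyond the scatter is expected in this assay for this smaller swap. The estimated step is small (a number 6 percentage points lower from compound 2 to compound 4 (within the scatter)), and the range is kept wider on the low side. Compound 4 is expected at 85% (estimated range 65% to 100%).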

Compound 4, percent of the compound remaining: 9%
Compound 4: the middle estimate sits 76 percentage points above what was measured, outside the stated range (below it).
By their numbers in this assay, from the lowest: compound 4; then compound 3; then compounds 2 and 1 (each within the scatter of the next).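

In this assay, going by these compounds alone, this position on the amide-type nitrogen proves far more sensitive than the earlier compounds suggested: cyclopropyl in place of isopropyl gives a large step (a number 82 percentage points lower from compound 2 to compound 4 (beyond the scatter)), although both groups carry 3 heavy atoms, all carbon, and the visible difference is the three-membered ring. Cyclopropyl in place of phenyl gives a similarly large step (a number 91 percentage points lower from compound 1 to compound 4 (beyond the scatter)), whereas isopropyl in place of phenyl gave only a small one (a number 9 percentage points lower from compound 1 to compound 2 (within the scatter)), so the similar values of compound 1 and compound 2 do not show that any group is accepted at this place. The data shown hold no independent measurement that accounts for the fall in compound 4, so the result stands as an observation only.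

Still open, as far as these compounds go, is whether the low number belongs to the three-membered ring specifically or extends to other carbon groups on this nitrogen, such as cyclobutyl, ethyl or a longer chain. A methyl group on the cyclopropyl ring, or an oxetane in its place, would also help show how narrowly the effect is tied to cyclopropyl itself.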